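A few compounds are considered here, and "the series" means these few. Any claim that something is new, unique, unknown or untested is made for them only; others in the source may bear on it.

Of the compounds shown here, two have been measured in a functional assay on SF-295 cells (Homo sapiens) for inhibition, read by sulforhodamine B assay, with a stated time of 48 h, tested at 10 uM; a lower number here means less inhibition, a higher number more inhibition at the concentration tested (going by the name of the read-out). Compound 1 `c1ccc2c(-c3cn4ccnc4c(-c4ccc5ncn(C6CCCCC6)c5c4)n3)cccc2c1` gives 6.34% in this assay, and compound 2 `Cc1cccc(-c2cn3ccnc3c(-c3ccc4ncn(Cc5ccccc5)c4c3)n2)c1` gives 14.3% in this assay. Compound 2 thus stands as the higher of the two numbers, but its nearest neighbour, compound 1, lies only a little lower, a gap that falls within the usual scatter of this measurement, so the two values cannot be ordered with confidence. For the measured compounds named here, compound 1 and compound 2 differ from one another in more than one place, so no single step between them can be drawn.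

Compound 3 `c1ccc(Cn2cnc3ccc(-c4nc(-c5cccc6ccccc56)cn5ccnc45)cc32)cc1` has not yet been measured in this assay. Compared with compound 2 it carries one change: naphthalen-1-yl in place of 3-methylphenyl on an aromatic carbon. Going by the values given here, no measured pair isolates this change, so the expectation rests on the low inhibition seen for both measured compounds. The step from compound 2 to compound 3 is expected to be small, a number 5.3 percentage points lower from compound 2 to compound 3 (within the scatter), and not beyond the scatter, with the direction uncertain. Compound 3 is accordingly estimated to give 9% in this assay, within a range from 0% to 25%.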

Compound 3, a percentage reported as inhibition, at one concentration (the size of the read-out at that concentration, not a potency): 8.22%
Compound 3: the middle estimate sits 0.8 percentage points above what was measured, and the stated range covers the measured number.
By their numbers in this assay, from the lowest: compounds 1, 3 and 2 (each within the scatter of the next).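

For the compounds shown here, with compound 3, the aromatic carbon on the six-membered aromatic ring with 2 nitrogen can be read through a single change for the first time: in this assay, naphthalen-1-yl in place of 3-methylphenyl, which adds a second six-membered aromatic ring of carbon, gives a step that cannot be told from the scatter (a number 6.1 percentage points lower from compound 2 to compound 3 (within the scatter)). Compound 3 also opens the aromatic nitrogen to a one-place reading, and there benzyl in place of cyclohexyl, with naphthalen-1-yl held constant, likewise stays inside the scatter (a number 1.9 percentage points higher from compound 1 to compound 3 (within the scatter)). Neither change therefore separates these compounds at the single concentration tested, and no measurement at hand offers an explanation for this.

As far as these compounds go, both steps exchange one hydrocarbon group for another, so it remains open whether a group bearing hydrogen-bond donors or acceptors, such as a morpholine or a carboxylic acid on the aromatic carbon, would read any differently. From the compounds shown here alone, it is equally open whether an aminoethyl chain in place of benzyl on the aromatic nitrogen would move the number beyond the scatter.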